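A few compounds are considered here, and "the series" means these few. Any claim that something is new, unique, unknown or untested is made for them only; others in the source may bear on it.

Measured compounds:
compound 1, `C[C@H](Nc1cc(F)c(S(=O)(=O)Nc2nccs2)cc1Cl)c1ccc(F)cc1`, with 30 mL/min/kg in an ADME assay on microsomes from liver (Homo sapiens) for metabolic stability, read by LC-MS, using NADPH, with a stated time of 60 min, tested at 1 uM; on this read-out higher numbers stand for fast clearance and lower numbers for slow clearance
compound 2, `C[C@H](Nc1cc(F)c(S(=O)(=O)Nc2nccs2)cc1Cl)c1ccc(F)cc1F`, with 9 mL/min/kg in this assay
compound 3, `C[C@H](Nc1cc(F)c(S(=O)(=O)Nc2cscn2)cc1Cl)c1ccccc1F`, with 51 mL/min/kg in this assay

Compound 1 and compound 2 share a core and differ in one place: fluoro in place of hydrogen on an aromatic carbon. This change gave a 3.3-fold lower number from compound 1 to compound 2 (0.52 log units; beyond the scatter). Compound 3 has the same atoms as compound 1 joined differently; the difference between the two cores is not broken down here. In this assay compound 3 and compound 1 lie within the scatter of each other, while compound 3 stands beyond the scatter from compound 2.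

Compound 4, `C[C@H](Nc1cc(F)c(S(=O)(=O)Nc2cscn2)cc1Cl)c1cc(F)ccc1F`, is not yet measured. It differs from compound 3 by fluoro in place of hydrogen on an aromatic carbon. This is the same kind of change as that from compound 1 to compound 2, but not the same: in compound 2 the entering fluoro sits ortho to a large group and meta to a fluoro group, whereas in compound 4 it sits meta to a large group and para to a fluoro group. For the measured compounds named here, the step from compound 3 to compound 4 in this assay is expected to be a 2.0-fold lower number from compound 3 to compound 4 (0.31 log units; beyond the scatter), a somewhat smaller move than the one seen because a 3.3-fold lower number from compound 1 to compound 2 (0.52 log units; beyond the scatter) was obtained at a different place on the ring, and only one such example exists. Compound 4 is therefore estimated at 25 mL/min/kg, most likely between 12 mL/min/kg and 50 mL/min/kg.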

Compound 4, clearance: 46 mL/min/kg
Compound 4: middle estimate off by 1.8-fold (0.26 log units), on the low side, and the stated range covers the measured number.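

In this assay, the fluoro that turns 2-fluorophenyl into 2,5-difluorophenyl gave a 1.1-fold lower number from compound 3 to compound 4 (0.04 log units; within the scatter), so on this core the change left the clearance number where it was. Set beside the earlier step, the same kind of change did not carry over in size from one core to the other: the same change on two cores in this assay, a 3.3-fold lower number (0.52 log units; beyond the scatter) from compound 1 to compound 2 and a 1.1-fold lower number (0.04 log units; within the scatter) from compound 3 to compound 4, 3.0-fold (0.48 log units) apart, beyond the scatter of two such steps. This shows that a step seen on one core in this series cannot simply be added to a compound on the other core, but it does not show that the core alone sets the outcome, since the entering fluoro also sits at a different place on the ring in the two steps, and two steps give no general rule.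

The compounds shown leave open whether a fluoro entering at the place it took in compound 2 would, on the core of compound 3, repeat the earlier step, which would separate the effect of the core from that of the place on the ring. They also leave open how a chloro, a methoxy or a nitrile at the place of the new fluoro in compound 4 would read in this assay.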